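From compound 3 to its 4-methylpiperazin-1-yl analogue

The compounds below may be only part of what the source reports. "The series", "measured", "known", "first", "only" and "open" are said of these compounds alone.

Among the measured compounds shown here, in a functional assay on K562 cells (Homo sapiens) for antiproliferative activity, read by MTT assay, with a stated time of 72 h (a higher number here means a weaker inhibitor, a lower number a stronger inhibitor), compound 3 (`O=C(/C=C/c1cccc(/C=C/C(=O)c2ccccc2)n1)NO`) gives 510 nM, the lowest of the three numbers so far. Compound 2 (`CN1CCN(c2ccc(C(=O)/C=C/c3cccc(/C=C/C(=O)NO)c3)cc2)CC1`) gives 1170 nM and compound 1 (`CN1CCN(c2ccccc2C(=O)/C=C/c2cccc(/C=C/C(=O)NO)c2)CC1`) gives 1290 nM. Each of these two numbers lies beyond the scatter from compound 3, and they lie within the scatter of each other.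

Compound 4 (`CN1CCN(c2ccccc2C(=O)/C=C/c2cccc(/C=C/C(=O)NO)n2)CC1`) has 4-methylpiperazin-1-yl in place of hydrogen on an aromatic carbon of compound 3, on a six-membered aromatic ring of carbon only, ortho to a large group: 4-methylpiperazin-1-yl in place of hydrogen on an aromatic carbon.

For the measured compounds named here, no measured pair isolates this change. Compound 1 carries the same group at the same kind of place, but its core differs from that of compound 4, so it offers only an indirect guide. With compound 1 at 1290 nM, a rise in the number from compound 3 is expected, meaning weaker inhibition, of moderate size and possibly not far beyond the scatter. The expected change is a 1.6-fold higher number from compound 3 to compound 4 (0.20 log units; within the scatter). The core difference leaves this direction uncertain. For compound 4 the estimated value is 800 nM, with an expected range from 300 nM to 2000 nM.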

Compound 4, half-maximal inhibitory concentration in the K562 assay: 700 nM
Compound 4: middle estimate off by 1.1-fold (0.06 log units), on the high side; the range from low to high includes it.
By their numbers in the K562 assay, from the lowest: compounds 3, 4, 2 and 1 (each within the scatter of the next, the first and the last beyond it).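

Among the compounds shown here, in the K562 assay, 4-methylpiperazin-1-yl in place of hydrogen on an aromatic carbon, ortho to a large group, gives a 1.4-fold higher number from compound 3 to compound 4 (0.14 log units; within the scatter), so this pair is the first direct reading of the change, and the number does not move beyond the scatter at this position. In a physicochemical assay for solubility, at pH 7.4 (a higher number here means a more soluble compound, a lower number a less soluble compound), compound 3 gives 16000 nM and compound 4 gives 450000 nM. For the compounds shown here, the same change thus gives a large rise in the number, a result that the earlier compounds could not supply: the measured solubility of compound 3, 16000 nM, and of compound 4, 450000 nM, a 28-fold higher number (1.45 log units; beyond the scatter). Read together, the two steps come apart on this single pair, with a large step in one read-out and none beyond the scatter in the other, so the group at this place is accommodated in the K562 assay while the solubility reading stands well apart from that of compound 3.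

Open, going by these compounds, is whether this split holds for morpholin-4-yl, or for a carboxylic acid, at the same place on the shared core. Also open, on these data alone, is whether 4-methylpiperazin-1-yl at another place on the same six-membered aromatic ring of carbon only gives the same pair of readings.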